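Working notes: compound 4 next to compound 3

The compounds below may be only part of what the source reports. "The series", "measured", "known", "first", "only" and "open" are said of these compounds alone.

Measured so far in a functional assay on L1210 cells (Mus musculus) for cytotoxicity, with a stated time of 48 h; a higher number here means a weaker inhibitor, a lower number a stronger inhibitor:
compound 1 `Fc1ccc(-c2cn3nc(Cc4ccc(Cl)cc4)sc3n2)cc1` gives > 250000 nM there.
For compound 1 this is a limit of the assay, not a number (the limit of > 250000 nM in this assay, at which 1 of the 3 values shown sits).
compound 2 `O=Cc1c(-c2ccc(F)cc2)nc2sc(Cc3ccc(Cl)cc3)nn12` gives 20000 nM there.
compound 3 `N#CSc1c(-c2ccc(F)cc2)nc2sc(Cc3ccc(Cl)cc3)nn12` gives 23000 nM there.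

Compound 3 holds the highest of the two numbers, with compound 2 within the scatter of it, a 1.2-fold higher number from compound 2 to compound 3 (0.06 log units; within the scatter). Compound 4 `COc1ccc(-c2nc3sc(Cc4ccc(Cl)cc4)nn3c2SC#N)cc1` differs from compound 3 by methoxy in place of fluoro on an aromatic carbon. The measured steps sit at another place: an at least 12-fold lower number from compound 1 to compound 2 (1.09 log units; beyond the scatter) and an at least 10-fold lower number from compound 1 to compound 3 (1.03 log units; beyond the scatter), both on the aromatic carbon carrying formyl or cyanosulfanyl, while a 1.2-fold higher number from compound 2 to compound 3 (0.06 log units; within the scatter) stays within the scatter. Going by the values given here, no measured step touches the 4-fluorophenyl, so nothing here points to a shift in this assay. For compound 4 the expected step is no change at the digits printed from compound 3 to compound 4 (within the scatter). Compound 4 is estimated at 23000 nM, with a range from 8000 nM to 70000 nM.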

Compound 4, half-maximal inhibitory concentration: 16000 nM
For compound 4 the middle estimate is 1.4-fold (0.16 log units) above the measured one; the range from low to high includes it.
By their numbers in this assay, from the lowest: compounds 4, 2 and 3 (each within the scatter of the next). At a limit, above all of these: compound 1.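

Methoxy in place of fluoro on the aromatic carbon gives, in this assay, a 1.4-fold lower number from compound 3 to compound 4 (0.16 log units; within the scatter), so this first change at the 4-fluorophenyl leaves the number within the scatter. The earlier steps shown here all lay on the aromatic carbon carrying formyl or cyanosulfanyl and gave no reading of this ring. No measured property available here bears on this result.

From the compounds shown here alone, whether 4-methoxyphenyl behaves the same with formyl in place of cyanosulfanyl stays open. So does the outcome with an amine, a carboxylic acid or a longer alkoxy chain in place of methoxy.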